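Amide for ketone at the carbonyl of compound 1

The compounds below may be only part of what the source reports. "The series", "measured", "known", "first", "only" and "open" are said of these compounds alone.

Measured compounds:
compound 1 `CC1=C(C(=O)C2CC2)C(c2cccs2)NC(=O)N1` — 1%
compound 2 `CC1=C(C(=O)C2CC2)C(c2ccsc2)NC(=O)N1` — 2%

Two compounds of the series have numbers in an assay on membranes from CHO cells for displacement of a labelled ligand from adenosine receptor A1 (Homo sapiens), read by scintillation counting, with a stated time of 60 min, tested at 1 uM; on this read-out higher numbers stand for more inhibition at the one concentration tested (going by the name of the read-out) and lower numbers for less inhibition. Among the measured compounds shown here, compound 1 gives 1% and compound 2 gives 2%; the step of a number 1 percentage points higher from compound 1 to compound 2 (within the scatter) leaves the two indistinguishable, so compound 1 stands together with compound 2 at the bottom of the read-out, with no measured compound clearly apart from it.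

The next compound, compound 3 `CCN(CC)C(=O)C1=C(C)NC(=O)NC1c1cccs1`, differs from compound 1 by diethylamino in place of cyclopropyl on a carbonyl carbon. For the measured compounds named here, no measured step touches this carbonyl carbon; the only step known changes the aromatic ring on the saturated ring carbon and stays within the scatter. The data therefore offer no reason to expect compound 3 to move beyond the scatter in this assay.

Compound 3 is estimated at 3%, with a range from 0% to 15%. The expected step is a number 2 percentage points higher from compound 1 to compound 3 (within the scatter), which is within the scatter.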

Compound 3, a percentage reported as inhibition, at one concentration (the size of the read-out at that concentration, not a potency): 13%
Compound 3: the middle estimate sits 10 percentage points below what was measured; the range from low to high includes it.
By their numbers in this assay, from the lowest: compounds 1 and 2 (each within the scatter of the next); then compound 3.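

In this assay, among the compounds shown here, the substituent on the carbonyl carbon is the first change to move the read-out beyond the scatter: diethylamino in place of cyclopropyl gives a number 12 percentage points higher from compound 1 to compound 3 (beyond the scatter). The change of aromatic ring, by contrast, gave only a number 1 percentage points higher from compound 1 to compound 2 (within the scatter), so this carbonyl carbon is so far the one place that responds, although compound 3 still reaches only 13% at the one concentration tested. Nothing available explains the rise.

For the compounds shown here, the single step swaps a ketone for an amide and a ring for an open chain at once, so an open-chain ketone such as a pentan-3-yl ketone, or a ring amide such as a piperidine amide, would be needed to separate the two. Also open, going by these compounds, is whether thiophen-3-yl gives a similar number when paired with the diethylamino amide.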